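The compounds below may be only part of what the source reports. "The series", "measured", "known", "first", "only" and "open" are said of these compounds alone.

Of the compounds shown here, three that share one core have been measured in a physicochemical assay for lipophilicity; on this read-out lower numbers stand for lower lipophilicity and higher numbers for higher lipophilicity. Compound 1 `Brc1cccc(Br)c1N(CC1CC1)C1=NCCN1` gives -1.12. Compound 2 `CCCN(C1=NCCN1)c1c(Br)cccc1Br` gives -0.55. Compound 3 `CC(C)N(C1=NCCN1)c1c(Br)cccc1Br` gives -0.82. Among these three numbers compound 2 stands highest: compound 3 lies nearest to it, and the gap between them, a number 0.27 log units lower from compound 2 to compound 3 (within the scatter), stays within the scatter, while the gap to compound 1, a number 0.57 log units higher from compound 1 to compound 2 (beyond the scatter), lies beyond it.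

The step in question leads from compound 2 to compound 4 `Brc1cccc(Br)c1N(Cc1ccccc1)C1=NCCN1`, a compound not yet measured in this assay. The change is phenyl in place of ethyl on a saturated chain carbon bound to a nitrogen on an aromatic ring.

Going by the values given here, one measured step touches the same carbon: a number 0.57 log units higher from compound 1 to compound 2 (beyond the scatter), where a ring gave way to an open chain. The change to compound 4 runs the other way, adding a six-membered aromatic ring of carbon only in place of ethyl, and it adds more heavy atoms than any step seen so far. Among the compounds with values here, no measured pair shows a phenyl entering, so the size must be judged from the steps above. A rise beyond the scatter is expected, larger than any step among compounds 1, 2 and 3: the expected step is a number 1.15 log units higher from compound 2 to compound 4 (beyond the scatter). Compound 4 is therefore estimated at 0.6, with a range from 0.1 to 1.1.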

Compound 4, distribution coefficient: -0.05
The estimate for compound 4 lay 0.65 log units above the measured number; measured number below the stated range.
By their numbers in this assay, from the lowest: compounds 1, 3 and 2 (each within the scatter of the next, the first and the last beyond it); then compound 4.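

In this assay the set now has a clear top, since phenyl in place of ethyl brings a number 0.50 log units higher from compound 2 to compound 4 (beyond the scatter) and benzyl in place of isopropyl on the same nitrogen brings a number 0.77 log units higher from compound 3 to compound 4 (beyond the scatter) in the same direction. Compound 1 also carries a ring on this saturated chain carbon, yet phenyl in place of cyclopropyl brings a number 1.07 log units higher from compound 1 to compound 4 (beyond the scatter) and this is the largest step among the four compounds, so across this pair the mere presence of a ring does not settle the number and the kind of ring makes a difference. Nothing shown here explains why the compounds fall in this order.

As far as these compounds go, whether the rise belongs to the aromatic ring itself or simply to the larger number of carbon atoms stays open, and cyclohexyl or a longer chain such as butyl on the same carbon would help separate the two. Also open, from the compounds shown here alone, is how the number would respond to a phenyl ring carrying a substituent such as an amine or a carboxylic acid, or to a pyridine ring in its place.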